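Pyridin-4-yl for Phenyl on Two Related Cores

The compounds below may be only part of what the source reports. "The series", "measured", "known", "first", "only" and "open" are said of these compounds alone.

Compound 1 `O=C1C(=O)N(Cc2ccc(-c3ccccc3)nc2)c2ccc(OC(F)(F)F)cc21`: 76%
Compound 2 `O=C1C(=O)N(Cc2ccc(-c3ccncc3)nc2)c2ccc(OC(F)(F)F)cc21`: 50%
Compound 3 `O=C1C(=O)N(Cc2ccc(-c3ccccc3)cc2)c2ccc(OC(F)(F)F)cc21`: reported only as a limit, < 60%

In a functional assay on CHO cells for positive allosteric modulation of muscarinic acetylcholine receptor M5 (Homo sapiens), read by FLIPR and calcium flux, with a stated time of 1 h (a higher number here means a larger maximal response, a lower number a smaller maximal response), compound 1 gives 76%. Compound 2 differs from it by pyridin-4-yl in place of phenyl on an aromatic carbon, and in this assay compound 2 gives 50%, a change of a number 26 percentage points lower from compound 1 to compound 2 (beyond the scatter). Compound 3 has a different core; the difference between the two cores is not broken down here. For compound 3 this assay gives only a limit, not a number, and compound 3 sits at the limit of < 60% in this assay, at which 1 of the 3 values shown sits.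

Compound 4 `O=C1C(=O)N(Cc2ccc(-c3ccncc3)cc2)c2ccc(OC(F)(F)F)cc21` differs from compound 3 by pyridin-4-yl in place of phenyl on an aromatic carbon. This is the same kind of change as that between compound 1 and compound 2, but the place is not the same: there the pyridin-4-yl sits on a six-membered aromatic ring with 1 nitrogen, next to the ring nitrogen, while here it sits on a ring of carbon only. The step expected is a step that the limit leaves unreadable from compound 3 to compound 4. This rests on a number 26 percentage points lower from compound 1 to compound 2 (beyond the scatter) and on compound 3 already sitting at a limit. Compound 4 is therefore estimated to give 40%, most likely between 20% and 60%, and probably reported only as a limit.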

Compound 4, largest response reached (Emax), in percent of the reference or control that the assay uses: 60%
The estimate for compound 4 lay 20 percentage points below the measured number; the range from low to high includes it.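

In this assay, pyridin-4-yl in place of phenyl gives a number no lower from compound 3 to compound 4 (the limit leaves the size open), so the loss seen on the core of compound 1 does not carry over unchanged to the core of compound 3: the same change on two cores in this assay, a number 26 percentage points lower (beyond the scatter) from compound 1 to compound 2 and a number no lower (the limit leaves the size open) from compound 3 to compound 4, at least 26 percentage points apart, beyond the scatter of two such steps. The reading for compound 3 is a limit and not a number: the limit of < 60% in this assay, at which 1 of the 4 values shown sits. The two pairs therefore show that the outcome of this change depends on the core it is made on, but they do not show how large the step on the second core is, whether it is a true gain, or which difference between the cores matters, and two pairs make no general rule.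

The compounds shown carry only phenyl or pyridin-4-yl as the outer ring, so it remains open how pyridin-3-yl, or a phenyl ring bearing an amine or a carboxylic acid, would behave on either core. The trifluoromethoxy group is also the same throughout, so the compounds shown leave open whether the difference between the two cores would persist with a group such as methoxy or chlorine in its place.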